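Swapping one chloro for fluoro on the dichlorophenyl compound

The source may report more compounds than this note shows. Statements on the series, on what has been measured and on what is new or still open speak of the compounds shown alone.

Measured in a functional assay on NCI/ADR-RES cells (Homo sapiens) for inhibition; on this read-out higher numbers stand for weaker inhibition of growth and lower numbers for stronger inhibition of growth:
compound 1 `N#Cc1ccc(/C=C/S(=O)(=O)Cc2ccc(Nc3ncnc4ccccc34)cc2)cc1`: > 100000 nM (a limit)
compound 2 `O=S(=O)(/C=C/c1ccc(Cl)cc1Cl)Cc1ccc(Nc2ncnc3ccccc23)cc1`: 5000 nM

Compound 1 sits at a limit of the assay, so it gives no number. Among the compounds with values here, that leaves compound 2, at 5000 nM, as the only number in this assay. Compound 3 `O=S(=O)(/C=C/c1ccc(F)cc1Cl)Cc1ccc(Nc2ncnc3ccccc23)cc1` differs from it by fluoro in place of chloro on an aromatic carbon, which turns 2,4-dichlorophenyl into 2-chloro-4-fluorophenyl. Within the data shown here, one measured step bears on this: an at least 20-fold lower number from compound 1 to compound 2 (1.30 log units; beyond the scatter). Its size is bounded by the limit of > 100000 nM in this assay, at which 1 of the 2 values shown sits. It shows that this aryl group can matter, but it exchanged 4-cyanophenyl for 2,4-dichlorophenyl, a wider change than one halogen. A much smaller step is therefore expected here, perhaps towards a slightly higher number. The expected step is a 1.4-fold higher number from compound 2 to compound 3 (0.15 log units; within the scatter). For compound 3 the estimated value is 7000 nM, within an expected range from 2500 nM to 25000 nM.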

Compound 3, concentration for 50% growth inhibition: 66000 nM
For compound 3 the middle estimate is 9.4-fold (0.97 log units) below the measured one, and the stated range ends below it.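

In this assay, this aromatic carbon, para to a large group, proves highly sensitive: a single halogen exchange, fluoro in place of chloro with the other chloro kept, gives a 13-fold higher number from compound 2 to compound 3 (1.12 log units; beyond the scatter), so the aryl group's influence does not depend on a change as wide as the earlier one. Against compound 1, the 2-chloro-4-fluorophenyl group gives an at least 1.5-fold lower number from compound 1 to compound 3 (0.18 log units; that floor lies within the scatter). Compound 1 stands at a limit, so that step sets only a floor: the limit of > 100000 nM in this assay, at which 1 of the 3 values shown sits.

The compounds shown leave open whether chloro itself is needed on this carbon or whether another group, such as bromo, methyl or methoxy, would serve equally well. They also leave open how a plain hydrogen here would compare, and whether the second chloro matters as much.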